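Carboxy to Amino at the End of a Long Tail

The compounds below may be only part of what the source reports. "The series", "measured", "known", "first", "only" and "open" are said of these compounds alone.

Three compounds sharing one core were tested in an assay on CHO cells for displacement of a labelled ligand from adenosine receptor A1 (Homo sapiens), read by scintillation counting, tested at 10 uM; a lower number here means less inhibition, a higher number more inhibition at the concentration tested (going by the name of the read-out). Compound 1 `CNC(=O)[C@@]12C[C@@H]1[C@@H](n1cnc3c(NCc4cccc(Cl)c4)nc(C#CCCC(=O)NCCNC(=O)CCCCC4SCC5NC(=O)NC54)nc31)[C@H](O)[C@@H]2O` gives 1%, compound 3 `CNC(=O)[C@@]12C[C@@H]1[C@@H](n1cnc3c(NCc4cccc(Cl)c4)nc(C#CCCCc4cn(-c5cccc([N+](=O)[O-])c5)nn4)nc31)[C@H](O)[C@@H]2O` gives 10%, and compound 2 `CNC(=O)[C@@]12C[C@@H]1[C@@H](n1cnc3c(NCc4cccc(Cl)c4)nc(C#CCCCCc4cn(-c5ccc(C(=O)O)cc5)nn4)nc31)[C@H](O)[C@@H]2O` gives 0%. Compound 2 holds the lowest number of the three, but its gaps to compound 1 and to compound 3 both lie within the scatter, so the three read as alike.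

Compound 4 `CNC(=O)[C@@]12C[C@@H]1[C@@H](n1cnc3c(NCc4cccc(Cl)c4)nc(C#CCCCCc4cn(-c5ccc(N)cc5)nn4)nc31)[C@H](O)[C@@H]2O` differs from compound 2 in one place: amino in place of carboxy on an aromatic carbon. With every tail so far giving little inhibition, the step from compound 2 to compound 4 is expected to be none beyond the scatter, a number 3 percentage points higher from compound 2 to compound 4 (within the scatter). Compound 4 is therefore estimated to give 3%, between 0% and 12%.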

Compound 4, a percentage reported as inhibition, at one concentration (the size of the read-out at that concentration, not a potency): 3%
For compound 4 middle estimate and measured number coincide at the digits printed; the measured number falls inside the stated range.
By their numbers in this assay, from the lowest: compounds 2, 1, 4 and 3 (each within the scatter of the next).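

Compounds differing in one place can now be compared, and this assay gives a number 3 percentage points higher from compound 2 to compound 4 (within the scatter) for amino in place of carboxy on an aromatic carbon. At this position, para to a large group, 4-carboxyphenyl and 4-aminophenyl therefore read as alike, although the two groups differ in their atoms. No measurement shown accounts for this result. Going by these compounds, whether a hydroxyl or a methyl ester at this position would also read alike remains open. So does whether amino would read the same with a shorter chain in the tail.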